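The source may hold more compounds than are shown below. What is called first, only, known or untested is meant among the compounds shown, and "the series" means these compounds.

Two compounds sharing a methylsulfonyl cyclopropyl group have numbers in a physicochemical assay for lipophilicity, using the shake flask method, in phosphate buffer, measured as octanol-water partition, with a stated time of 3 h, at pH 7.4, tested at 10 uM; on this read-out higher numbers stand for higher lipophilicity and lower numbers for lower lipophilicity. Compound 1 `CS(=O)(=O)C1(c2cc(C3=CCOCC3)nc(-c3cccc4[nH]ccc34)n2)CC1` gives 2.9, while compound 2 `CS(=O)(=O)C1(c2cc(N3CC4CCC(C3)O4)nc(-c3cncc4[nH]ccc34)n2)CC1` gives 2.2. Compound 2 therefore holds the lower of the two numbers, and the gap between them lies beyond the scatter of repeated measurements. These two compounds differ in more than one place, so their gap does not isolate the effect of any single change.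

Compound 3 `CS(=O)(=O)C1(c2cc(N3C4CCC3COC4)nc(-c3cncc4[nH]ccc34)n2)CC1` departs from compound 2 in one group only: a group of 8 heavy atoms (6 carbon, 1 nitrogen, 1 oxygen; one five-membered non-aromatic ring with 1 hetero atom, one six-membered non-aromatic ring with 2 hetero atoms) in place of a group of 8 heavy atoms (6 carbon, 1 nitrogen, 1 oxygen; one five-membered non-aromatic ring with 1 hetero atom, one six-membered non-aromatic ring with 2 hetero atoms), on an aromatic carbon. The two compounds have the same atoms, joined differently, and the change sits on an aromatic carbon, next to the ring nitrogen.

For the measured compounds named here, no measured single-place step is available as a guide, and the two groups match in every count. The closest reference is therefore compound 2 at 2.2, and no shift beyond the scatter is expected. The expected step is small, a number 0.10 log units higher from compound 2 to compound 3 (within the scatter), and it is upward only nominally. For compound 3 the estimated value is 2.3, with an expected range of 1.9 to 2.7.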

Compound 3, distribution coefficient: 2.1
Compound 3: the middle estimate sits 0.20 log units above what was measured; low and high end bracket the measured number.
By their numbers in this assay, from the lowest: compounds 3 and 2 (each within the scatter of the next); then compound 1.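

In this assay, the exchange gives a number 0.10 log units lower from compound 2 to compound 3 (within the scatter), so joining the same atoms differently on this aromatic carbon, next to the ring nitrogen, leaves the read-out unresolved between the two groups. For the compounds shown here, this is the first comparison in the set that isolates one place, as compound 1 and compound 2 differ in more than one, and it shows that two groups matching in heavy atoms, ring types, hydrogen-bond donors and hydrogen-bond acceptors can be interchanged here without a step beyond the scatter. No measured property is available that could account for this result.

The compounds shown cover only this one exchange between groups of identical atom counts, so it remains open how this assay would respond at this position to a group with different counts, such as a morpholine, a dimethylamino group or a longer ether chain. As far as these compounds go, it also remains open whether the same exchange would stay within the scatter on the core of compound 1, or at the position held by the 1-(methylsulfonyl)cyclopropyl group.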